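Sulfanyl side-chain variation on the shared core

The compounds below may be only part of what the source reports. "The series", "measured", "known", "first", "only" and "open" are said of these compounds alone.

Measured so far:
compound 1 `CC(O)CSc1nc(NCc2ccc(-c3ccccn3)cc2)c2[nH]nc(C(C)C)c2n1`: 62 nM
compound 2 `CC(C)c1n[nH]c2c(NCc3ccc(-c4ccccn4)cc3)nc(SCC(C)(C)O)nc12`: 507 nM
compound 3 `CC(C)c1n[nH]c2c(NCc3ccc(-c4ccccn4)cc3)nc(SC(C)C(C)O)nc12`: 190 nM

In a functional assay on HT cells (Homo sapiens) for antiproliferative activity, read by fluorescence, with a stated time of 72 h (a lower number here means a stronger inhibitor of growth, a higher number a weaker inhibitor of growth), compound 2 stands as the weakest of the three, with the steps of an 8.2-fold higher number from compound 1 to compound 2 (0.91 log units; beyond the scatter) and a 2.7-fold lower number from compound 2 to compound 3 (0.43 log units; beyond the scatter) both beyond the scatter. Compound 4 `COCSc1nc(NCc2ccc(-c3ccccn3)cc2)c2[nH]nc(C(C)C)c2n1` is the next member; its change from compound 2 is methoxy in place of 1-hydroxy-1-methylethyl on a saturated chain carbon bound to a sulfur. Among the compounds with values here, no measured step removes a hydroxyl group, so that part of the change is unsupported by data. The steps of an 8.2-fold higher number from compound 1 to compound 2 (0.91 log units; beyond the scatter) and a 3.1-fold higher number from compound 1 to compound 3 (0.49 log units; beyond the scatter) show that adding a methyl to this chain raised the number, so the shortened methoxymethyl chain of compound 4 is expected to give a lower number, by a modest margin. For compound 4 the estimate in this assay is 150 nM, within 40 nM to 550 nM, meaning an expected step of a 3.4-fold lower number from compound 2 to compound 4 (0.53 log units; beyond the scatter).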

Compound 4, concentration for 50% growth inhibition: 340 nM
Estimate against measurement, compound 4: 2.3-fold (0.36 log units) below; measured number inside the range.
By their numbers in this assay, from the lowest: compound 1; then compounds 3, 4 and 2 (each within the scatter of the next, the first and the last beyond it).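

In this assay methoxy in place of 1-hydroxy-1-methylethyl on a saturated chain carbon bound to a sulfur stays within the scatter (a 1.5-fold lower number from compound 2 to compound 4 (0.17 log units; within the scatter)), as does methoxymethyl in place of 2-hydroxy-1-methylpropyl on a sulfur (a 1.8-fold higher number from compound 3 to compound 4 (0.25 log units; within the scatter)). The hydroxyl group can therefore go without a step beyond the scatter from these branched chains, whereas the unbranched chain of compound 1 remains clearly apart (a 5.5-fold higher number from compound 1 to compound 4 (0.74 log units; beyond the scatter)). No available evidence explains these differences.

From the compounds shown here alone, whether an amine, a carboxylic acid or a longer chain on the sulfur would reach the level of compound 1 remains open.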